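Fluoro in place of methoxy: compound 3 to compound 4

The source may report more compounds than this note shows. Statements on the series, on what has been measured and on what is new or still open speak of the compounds shown alone.

Measured in a functional assay on SK-OV-3 cells (Homo sapiens) for cytotoxicity; on this read-out higher numbers stand for weaker inhibition of growth and lower numbers for stronger inhibition of growth:
- compound 1 `COc1ccc(C2=C(c3ccc(SC)cc3)CC3CCCN3C2=O)cc1O`: > 100000 nM
- compound 2 `COc1ccc(C2=C(c3ccc(SC)cc3)CC3CCCN3C2=O)cc1OC(=O)CNC(=O)OC(C)(C)C`: 20000 nM
- compound 3 `COc1ccc(C2=C(c3ccc(SC)cc3)CC3CCCN3C2=O)cc1C`: 15000 nM

The entry for compound 1 is a limit and not a number (the limit of > 100000 nM in this assay, at which 1 of the 3 values shown sits). Among the measured compounds shown here, only two true numbers exist in this assay, and they cannot be told apart: a 1.3-fold lower number from compound 2 to compound 3 (0.12 log units; within the scatter). Compound 3 therefore stands level with compound 2, and both sit clear of the limit.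

The next structure is compound 4 `CSc1ccc(C2=C(c3ccc(F)c(C)c3)C(=O)N3CCCC3C2)cc1`, reached from compound 3 by fluoro in place of methoxy on an aromatic carbon. In words, this is fluoro in place of methoxy on an aromatic carbon, turning 4-methoxy-3-methylphenyl into 4-fluoro-3-methylphenyl.

For the measured compounds named here, no measured step touches the methoxy itself, so the evidence is indirect. The nearest steps change another group on the same aromatic ring: an at least 5.0-fold lower number from compound 1 to compound 2 (0.69 log units; beyond the scatter) and an at least 6.6-fold lower number from compound 1 to compound 3 (0.82 log units; beyond the scatter). As far as these compounds go, both run from a limit, so their true sizes remain open. They show that this ring can move the read-out, but not what a change at the methoxy does.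

Going by the values given here, with no direct precedent, the working expectation is no shift beyond the scatter, though the uncertainty is wide: a 1.3-fold higher number from compound 3 to compound 4 (0.12 log units; within the scatter) is the expected step. For compound 4 the estimated value in this assay is 20000 nM, with an expected range of 6000 nM to 70000 nM.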

Compound 4, concentration for 50% growth inhibition: 300 nM
For compound 4 the middle estimate is 67-fold (1.82 log units) above the measured one; measured number outside the range, below it.
By their numbers in this assay, from the lowest: compound 4; then compounds 3 and 2 (each within the scatter of the next). At a limit, above all of these: compound 1.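

In this assay, the position para to the large group, held by methoxy in compounds 1 to 3, proves far more sensitive than the opening evidence could show: a 50-fold lower number from compound 3 to compound 4 (1.70 log units; beyond the scatter), with the methyl group ortho to it unchanged. The entry for compound 1 is a limit and not a number: the limit of > 100000 nM in this assay, at which 1 of the 4 values shown sits. The step of an at least 330-fold lower number from compound 1 to compound 4 (2.52 log units; beyond the scatter) therefore gives only a minimum size, and it covers the whole change from 3-hydroxy-4-methoxyphenyl to 4-fluoro-3-methylphenyl, so it cannot be assigned to either ring position alone.

The compounds shown leave open whether the lower number follows from fluoro itself or simply from the loss of methoxy, a question that hydrogen, chloro or trifluoromethyl on the same aromatic carbon would help to settle. Among the compounds shown here, also open is how much the neighbouring methyl group contributes once fluoro is present, since compound 4 is the only fluoro compound here and a hydroxy, chloro or amine in place of that methyl would test this.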